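A few compounds are considered here, and "the series" means these few. Any claim that something is new, unique, unknown or untested is made for them only; others in the source may bear on it.

Among the measured compounds shown here, compound 1 `Cc1ccc(-c2nn(-c3ccccc3)cc2C(=O)NC(=S)Nc2ccc(Cl)cc2)cc1` is one of three compounds measured in a functional assay on MCF7 cells (Homo sapiens) for inhibition, read by CCK-8 assay, with a stated time of 48 h (on this read-out higher numbers stand for weaker inhibition and lower numbers for stronger inhibition), and in this assay compound 1 gives 6210 nM, the highest of the three numbers. For the measured compounds named here, compound 2 `Cc1ccc(NC(=S)NC(=O)c2cn(-c3ccccc3)nc2-c2ccc(C)cc2)cc1` gives 5660 nM, and the step of a 1.1-fold lower number from compound 1 to compound 2 (0.04 log units; within the scatter) is the only single change among the measured compounds; it is a methyl in place of a chloro on an aromatic carbon. Compound 3 `COc1ccc(-c2nn(-c3ccccc3)cc2C(=O)NC(=S)Nc2ccc(F)cc2)cc1` gives 4990 nM, and all three numbers sit within the scatter of one another, so none can be called stronger or weaker.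

Compound 4 `O=C(NC(=S)Nc1ccc(Cl)cc1)c1cn(-c2ccccc2)nc1-c1ccc(F)cc1` differs from compound 1 in a single place: fluoro in place of methyl on an aromatic carbon. The change sits on the 4-methylphenyl ring, which becomes 4-fluorophenyl. Going by the values given here, no measured step covers this change; the one measured step exchanges methyl and chloro on the other aromatic ring, and it stayed within the scatter. Compound 3 carries a fluoro and a methoxy and also lies within the scatter of compound 1. On this basis the step is expected to be a 1.1-fold lower number from compound 1 to compound 4 (0.03 log units; within the scatter), that is, no step beyond the scatter. Compound 4 is therefore estimated at 5800 nM, with a range from 2500 nM to 13000 nM.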

Compound 4, half-maximal inhibitory concentration: 5470 nM
Beside the measured number, compound 4's estimate is 1.1-fold (0.03 log units) above it; low and high end bracket the measured number.
By their numbers in this assay, from the lowest: compounds 3, 4, 2 and 1 (each within the scatter of the next).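

Among the compounds shown here, the first direct reading at the 4-methylphenyl ring comes in this assay as a 1.1-fold lower number from compound 1 to compound 4 (0.06 log units; within the scatter), so a change to 4-fluorophenyl at this place cannot be told apart from compound 1 on this read-out. For the compounds shown here, until now the only single change sat on the other aromatic ring, where methyl took the place of chloro; each of the two rings now has one such change, and neither step goes beyond the scatter. Nothing measured here bears on the reason for this result.

Methyl and fluoro each count as one heavy atom, so it remains open whether a larger group at this place, such as a tert-butyl, or a group of another kind, such as an amine or a carboxylic acid, would move the number beyond the scatter. From the compounds shown here alone, the fluoro of compound 4 sits para to a large group, and how the same group would read at another place on that ring also remains open.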